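This account rests on a few compounds, and the source may have more. Where it says the series, first, only, none or still open, it means among the compounds named here.

Compound 3 `Cc1ccc(-c2cnc(Nc3cccc4c3CC(O)CC4)o2)cc1` stands lowest of the three numbers in an in vitro functional assay on cells for antagonist activity at transient receptor potential cation channel subfamily V member 1 (Homo sapiens), read by FLIPR and calcium flux (a higher number here means a weaker inhibitor, a lower number a stronger inhibitor), where compound 3 gives 62 nM. Compound 1 `OC1CCc2cccc(Nc3ncc(-c4ccccc4)o3)c2C1` gives 187 nM in this assay, and compound 2 `Cc1ccccc1-c1cnc(Nc2cccc3c2CC(O)CC3)o1` gives 416 nM. The measured steps are a 3.0-fold lower number from compound 1 to compound 3 (0.48 log units; beyond the scatter), a 2.2-fold higher number from compound 1 to compound 2 (0.35 log units; beyond the scatter) and a 6.7-fold lower number from compound 2 to compound 3 (0.83 log units; beyond the scatter), so the 4-methylphenyl compound 3 sits clearly apart from both others.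

Compound 4 `OC1CCc2cccc(Nc3ncc(-c4ccc(Cl)cc4)o3)c2C1` differs from compound 3 by chloro in place of methyl on an aromatic carbon. Going by the values given here, no measured pair swaps methyl for chloro, so the closest guide is the pair compound 1 to compound 3, where a methyl entering at this aromatic carbon gave a 3.0-fold lower number from compound 1 to compound 3 (0.48 log units; beyond the scatter); the step from compound 1 to compound 2 shows that a methyl at a different position of that ring went the other way. A chloro at the same place as the methyl of compound 3 is expected to stay close to compound 3, with any shift in this assay within the scatter. Compound 4 is therefore estimated at 70 nM, with a range from 30 nM to 180 nM. The expected step is a 1.1-fold higher number from compound 3 to compound 4 (0.05 log units; within the scatter).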

Compound 4, half-maximal inhibitory concentration: 15 nM
Compound 4: the middle estimate sits 4.7-fold (0.67 log units) above what was measured, outside the stated range (below it).
By their numbers in this assay, from the lowest: compound 4; then compound 3; then compound 1; then compound 2.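

In this assay the group at this place, para to a large group, matters by its identity and not only by its presence: the change from 4-methylphenyl to 4-chlorophenyl gives a 4.1-fold lower number from compound 3 to compound 4 (0.62 log units; beyond the scatter) and so methyl and chloro are not interchangeable here. Set against hydrogen on the same carbon, chloro gives a 12-fold lower number from compound 1 to compound 4 (1.10 log units; beyond the scatter) and goes further than methyl with a 3.0-fold lower number from compound 1 to compound 3 (0.48 log units; beyond the scatter) while the distance from the 2-methylphenyl compound grows to a 28-fold lower number from compound 2 to compound 4 (1.44 log units; beyond the scatter) as the widest step in this set. Nothing at hand accounts for this order of hydrogen, methyl and chloro.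

Only these three groups are shown on this carbon, so whether fluoro, bromo, trifluoromethyl, methoxy or an amine would match compound 4 stays open. Also open, as far as these compounds go, is whether the gain from chloro carries over to a core without the hydroxyl of compound 4.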